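Swapping Chloro for Methoxy on the Pendant Phenyl

This account rests on a few compounds, and the source may have more. Where it says the series, first, only, none or still open, it means among the compounds named here.

Among the measured compounds shown here, compound 2 `COc1c(OCCCCN2CCN(C)CC2)cc(O)c2c(=O)cc(-c3ccc(Cl)cc3)oc12` gives 3750 nM in a functional assay on HepG2 cells (Homo sapiens) for cytotoxicity, read by MTT assay, with a stated time of 72 h (on this read-out lower numbers stand for stronger inhibition and higher numbers for weaker inhibition), the highest of the three numbers measured so far; compound 3 `COc1c(OCCCCN2CCN(C)CC2)cc(O)c2c(=O)cc(-c3ccc(C(F)(F)F)cc3)oc12` with 2400 nM stands nearest, and compound 1 `COc1c(OCCCCN2CCN(C)CC2)cc(O)c2c(=O)cc(-c3ccc(C)cc3)oc12` with 1000 nM furthest. Among the measured steps, a 3.8-fold higher number from compound 1 to compound 2 (0.57 log units; beyond the scatter) and a 2.4-fold higher number from compound 1 to compound 3 (0.38 log units; beyond the scatter), while a 1.6-fold lower number from compound 2 to compound 3 (0.19 log units; within the scatter). Compound 4 `COc1ccccc1-c1cc(=O)c2c(O)cc(OCCCCN3CCN(C)CC3)c(OC)c2o1` differs from compound 2 by 2-methoxyphenyl in place of 4-chlorophenyl on an aromatic carbon. For the measured compounds named here, no measured step alters the pendant ring in the way this one does, so the steps bearing on it show only that the three aryl variants spread over a modest range in this assay. A step no larger than that range is therefore expected for compound 4, its direction uncertain, a 1.5-fold lower number from compound 2 to compound 4 (0.18 log units; within the scatter). Compound 4 is estimated at 2500 nM, between 1000 nM and 6500 nM.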

Compound 4, half-maximal inhibitory concentration: 2330 nM
Compound 4: middle estimate off by 1.1-fold (0.03 log units), on the high side, and the stated range covers the measured number.
By their numbers in this assay, from the lowest: compound 1; then compounds 4, 3 and 2 (each within the scatter of the next).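

In this assay, the 2-methoxyphenyl ring, the only variant here with a hydrogen-bond acceptor, falls in with the 4-chlorophenyl and 4-(trifluoromethyl)phenyl rings, with a 1.6-fold lower number from compound 2 to compound 4 (0.21 log units; within the scatter) and a 1.0-fold lower number from compound 3 to compound 4 (0.01 log units; within the scatter). The 4-methylphenyl ring alone stands apart, with a 2.3-fold higher number from compound 1 to compound 4 (0.37 log units; beyond the scatter), so compound 1 keeps the lowest number of the four. No evidence at hand accounts for this pattern. The compounds shown do not separate the methoxy group itself from where it sits on the ring. They also leave open how an amine or a carboxylic acid on the pendant ring would read.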